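This account rests on a few compounds, and the source may have more. Where it says the series, first, only, none or still open, it means among the compounds named here.

Measured compounds in a functional assay on HTB-54 cells (Homo sapiens) for cytotoxicity, read by MTT assay, with a stated time of 72 h; on this read-out lower numbers stand for stronger inhibition of growth and higher numbers for weaker inhibition of growth:
Compound 1 `C[Se]c1nc(N)c2ccccc2n1` gives 88700 nM.
Compound 2 `CCCCCSc1nc(NCc2ccc([Se]C)cc2)c2ccccc2n1` gives 50000 nM.
Compound 3 `CSc1nc(NCc2ccc([Se]C)cc2)c2ccccc2n1` reaches only the assay limit, > 100000 nM.

Compound 3 stands at the limit, which is where the limit of > 100000 nM in this assay, at which 1 of the 3 values shown sits, applies, so it gives a range rather than a number. Compound 4 `CSc1nc(NCc2ccccc2)c2ccccc2n1` differs by a hydrogen atom in place of a group of 2 heavy atoms (1 carbon, 1 selenium; no ring), on an aromatic carbon, para to a large group. Among the measured compounds shown here, no measured step touches this position; the only measured step, an at least 2.0-fold higher number from compound 2 to compound 3 (0.30 log units; that floor lies within the scatter), concerns the chain on the sulfur and sits within the scatter. Compound 4 is therefore expected to stay near the limit, with a number no higher from compound 3 to compound 4 (the limit leaves the size open) as the estimated step, and an expected value of 100000 nM (range 50000 nM to 200000 nM).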

Compound 4, concentration for total growth inhibition: 82300 nM
For compound 4 the middle estimate is 1.2-fold (0.08 log units) above the measured one; the measured number falls inside the stated range.
By their numbers in this assay, from the lowest: compounds 2, 4 and 1 (each within the scatter of the next). At a limit, above all of these: compound 3.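

In this assay, a hydrogen atom in place of the group of 2 heavy atoms (1 carbon, 1 selenium; no ring), on an aromatic carbon, gives an at least 1.2-fold lower number from compound 3 to compound 4 (0.08 log units; that floor lies within the scatter). For compound 3, the value of > 100000 nM is a limit. This is the first change at this position among the compounds shown, and its full size cannot be read because one end of the step is not a number: the limit of > 100000 nM in this assay, at which 1 of the 4 values shown sits.

The compounds shown leave open how an amine, a methoxy group or a chlorine atom would read at this position. They also leave open whether the same change would read differently with a pentyl chain on the sulfur.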